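The compounds below may be only part of what the source reports. "The series", "measured", "known", "first", "only" and "open" are said of these compounds alone.

Two compounds have been measured in a toxicity assay on L02 cells (Homo sapiens) for cytotoxicity, read by CCK-8 assay, with a stated time of 72 h; a lower number here means a stronger inhibitor, a higher number a weaker inhibitor:

Compound 1 `CC(C)(C)OC(=O)/C=C1/C(=O)Nc2ccccc21` gives 2450 nM.
Compound 2 `CN1C(=O)/C(=C/C(=O)OC(C)(C)C)c2ccccc21` gives 4320 nM.

Compound 1 has the lowest of these two numbers, and the only other one is a 1.8-fold higher number from compound 1 to compound 2 (0.25 log units; within the scatter), a step made by methyl in place of hydrogen on an amide-type nitrogen in a ring and one that stays within the scatter. Compound 3 `CC(C)(C)OC(=O)/C=C1/C(=O)Nc2ccc([N+](=O)[O-])cc21` differs from compound 1 by nitro in place of hydrogen on an aromatic carbon. For the measured compounds named here, no measured step changes anything on that aromatic ring, so the single known step, a 1.8-fold higher number from compound 1 to compound 2 (0.25 log units; within the scatter), bears on it only by showing that the shared core kept a similar number when altered elsewhere. With nothing pointing in either direction, compound 3 is expected to stay near compound 1, a step of a 1.2-fold lower number from compound 1 to compound 3 (0.09 log units; within the scatter) that should be no larger than the scatter. The estimate for compound 3 is 2000 nM, in the range 700 nM to 6000 nM.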

Compound 3, half-maximal inhibitory concentration: 3820 nM
Compound 3: middle estimate off by 1.9-fold (0.28 log units), on the low side; the measured number falls inside the stated range.
By their numbers in this assay, from the lowest: compounds 1, 3 and 2 (each within the scatter of the next).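

Swapping hydrogen for nitro on the aromatic ring gives, in this assay, a 1.6-fold higher number from compound 1 to compound 3 (0.19 log units; within the scatter) and so leaves compound 1 and compound 3 indistinguishable in this measurement. For the compounds shown here, the earlier step altered only the amide-type nitrogen, so this is the first sign that the aromatic ring of the shared core can carry an added group of several heavy atoms without a readable shift in the number. No measurement offered here accounts for this result.

As far as these compounds go, whether a different group on this same carbon, such as an amine, a carboxylic acid or a chlorine, would shift the number beyond the scatter remains open. So does whether nitro would behave the same way on another carbon of the ring, or when combined with the methyl on the ring nitrogen.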